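The compounds below may be only part of what the source reports. "The series", "measured", "known", "first", "only" and "open" are said of these compounds alone.

Measured so far in an ADME assay on microsomes from liver (Mus musculus) for metabolic stability, read by LC-MS, with a stated time of 30 min, tested at 1 uM; a higher number here means that more of the compound is left, a lower number that less of the compound is left:
- compound 1 `O=C(NCc1ccc(S(=O)(=O)c2cc(F)cc(F)c2)cc1)c1cc2ccncc2o1`: 12%
- compound 2 `O=C(NCc1ccc(S(=O)(=O)N2CCCCC2)cc1)c1cc2ccncc2o1`: 0.14%
- compound 3 `O=C(NCc1ccc(S(=O)(=O)N2CCCCC2)cc1)c1cc2cnccc2o1`: 4.6%

Compound 2 sits at the low end of this small set. Compound 3 lies within the usual scatter of it, while compound 1 stands beyond the scatter, as the step of a number 11.9 percentage points lower from compound 1 to compound 2 (beyond the scatter) shows. The step of a number 4.5 percentage points higher from compound 2 to compound 3 (within the scatter) stays within the scatter.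

Compound 4 `O=C(NCc1ccc(S(=O)(=O)c2cccc(C(F)(F)F)c2)cc1)c1cc2ccncc2o1` is the next candidate for this assay. It differs from compound 2 in one place: 3-(trifluoromethyl)phenyl in place of piperidin-1-yl on a sulfonyl sulfur. Within the data shown here, the only measured step that bears on this change is the one from compound 1 to compound 2, where an aromatic ring on the sulfonyl sulfur gave way to piperidin-1-yl and the reading fell by a number 11.9 percentage points lower from compound 1 to compound 2 (beyond the scatter). Among the measured compounds shown here, compound 4 goes the other way, putting an aromatic ring back on the sulfonyl sulfur, so an upward step of roughly that size is expected, with a wide range because only one such step is known. For compound 4 the expected step is a number 7.9 percentage points higher from compound 2 to compound 4 (within the scatter), giving an estimate of 8%, between 1% and 25%.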

Compound 4, percent of the compound remaining: 64%
Compound 4: the middle estimate sits 56 percentage points below what was measured, outside the stated range (above it).
By their numbers in this assay, from the lowest: compounds 2, 3 and 1 (each within the scatter of the next, the first and the last beyond it); then compound 4.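

In this assay, the group on the sulfonyl sulfur can decide the reading: 3-(trifluoromethyl)phenyl in place of piperidin-1-yl gives a number 63.9 percentage points higher from compound 2 to compound 4 (beyond the scatter). An aromatic ring in this place does not settle the outcome by itself, as 3-(trifluoromethyl)phenyl in place of 3,5-difluorophenyl still gives a number 52 percentage points higher from compound 1 to compound 4 (beyond the scatter), so what the ring carries also counts. Nothing measured here explains either step.

The compounds shown leave open whether the trifluoromethyl group is needed for this reading, or whether a phenyl ring bearing a chlorine, a methoxy group or a nitrile would serve as well. They also leave open whether 3-(trifluoromethyl)phenyl would give a similar reading on the core of compound 3.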